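This account rests on a few compounds, and the source may have more. Where it says the series, first, only, none or still open, it means among the compounds named here.

The shared core of this set appears in compound 1 `C=C[C@@](C)(/C=C/c1ccc(OCc2ccccc2)cc1)CCC=C(C)C`. In an ADME assay on HEK293 cells (Homo sapiens) for cytotoxicity, with a stated time of 72 h (a lower number here means that less compound is needed, a higher number that more compound is needed for the effect), compound 1 gives > 36600 nM, which is a limit of the assay and not a number. Compound 2 `C=C[C@@](C)(/C=C/c1ccc(O)cc1)CCCO` is a second member of the set. In this assay compound 2 gives > 36600 nM, again only a limit. Compound 3 `CCOC(=O)/C=C/c1cc(/C=C/[C@](C)(/C=C/c2ccc(OC)cc2)CCC=C(C)C)ccc1O` completes the measured members. In this assay compound 3 gives > 36600 nM, which is likewise a limit. Going by the values given here, compound 1 therefore stands exactly where the whole measured set stands, at the limit of > 36600 nM in this assay, at which 3 of the 3 values shown sit, and no compound can be set above or below another. No two of these compounds differ in a single place, so no measured step between them can be drawn.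

Compound 4 `C=C[C@@](C)(/C=C/c1ccc(Nc2ccc(Cl)cc2)cc1)CCC=C(C)C` has not yet been measured. It differs from compound 1 in one place: (4-chlorophenyl)amino in place of benzyloxy on an aromatic carbon. Because the three measured values all sit at the limit of > 36600 nM in this assay, at which 3 of the 3 values shown sit, there is no sign of a change beyond the scatter anywhere in this set. Accordingly the step from compound 1 to compound 4 in this assay is expected to be an at least 1.2-fold lower number from compound 1 to compound 4 (0.08 log units; that floor lies within the scatter), that is, essentially none beyond the scatter. For compound 4 the value in this assay is estimated at 30000 nM, with a range from 8000 nM to 60000 nM.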

Compound 4, half-maximal effective concentration: > 36600 nM
Compound 4: a limit, no number (the forecaster's own chance of this, stated with the estimate: 65%); middle value at least 1.2-fold (0.08 log units) away from the limit.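

In this assay compound 4 gives > 36600 nM, which is a limit of the assay and not a number. Going by these compounds alone, compound 1 also stands at a limit, so no step between compound 1 and compound 4 can be read. The compounds shown leave open whether any change to the shared core would give a measurable value, since all remain at the limit: the limit of > 36600 nM in this assay, at which 4 of the 4 values shown sit.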